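The compounds below may be only part of what the source reports. "The series", "measured", "known", "first", "only" and "open" are said of these compounds alone.

For the measured compounds named here, the three compounds measured so far share one core and are all read in a functional assay on the whole organism (strain Wistar) for inhibition, with Rattus norvegicus as the target, read by paw edema, with stated times of 1 h and 24 h, at a dose of 10 mg/kg by the intraperitoneal route; on this read-out lower numbers stand for less inhibition and higher numbers for more inhibition at the one dose given (going by the name of the read-out). Compound 1, drawn as `Cc1ncc([N+](=O)[O-])n1CCOC(=O)c1cc(NC(=O)C(C)NC(=O)OCc2ccccc2)ccc1O`, gives 0% in this assay. Compound 2, with the structure `CC(=O)Nc1ccc(O)c(C(=O)OCCn2c([N+](=O)[O-])cnc2C)c1`, gives 0% in this assay, and compound 3, with the structure `CC(=O)Nc1ccc(O)c(C(=O)O)c1`, gives 0% in this assay. On these numbers compound 1 stands level with compounds 2 and 3 at the digits shown: its nearest neighbour is compound 2, with no change at those digits and within the usual scatter, and its furthest is compound 3, again with no change at those digits and within the scatter. Going by the values given here, no pair of measured compounds differs in only one place, so no measured step is available to scale an expectation.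

The next compound, compound 4 with the structure `Cc1ncc([N+](=O)[O-])n1CCOC(=O)c1cc(NC(=O)[C@H](C)NC(=O)OCc2ccccc2)ccc1O`, is related to compound 1 as follows: the two compounds have the same atoms and bonds; at least one stereo element is drawn with a configuration in one of them and without one in the other: 1 of 1 stereo elements differ; a stereocentre at a saturated chain carbon is drawn without a configuration in compound 1 and S in compound 4. Since compound 1 gives 0% and nothing in the measured set moves away from that level, compound 4 is expected to show no step beyond the scatter, the expected step being no change at the digits printed from compound 1 to compound 4 (within the scatter). Compound 4 is therefore estimated at 0% in this assay, with an expected range from -5% to 10%.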

Compound 4, a percentage reported as inhibition, in the whole organism at one dose (the size of the read-out at that dose, not a potency): 11.6%
Beside the measured number, compound 4's estimate is 11.6 percentage points below it; measured number outside the range, above it.
By their numbers in this assay, from the lowest: compounds 1, 2 and 3 (each within the scatter of the next); then compound 4.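

In this assay, for the compounds shown here, this stereocentre gives the first measured step in the set: a number 11.6 percentage points higher from compound 1 to compound 4 (beyond the scatter). Going by these compounds alone, until this pair, no two compounds differed in only one place, and every value sat at the same level, so nothing showed that the read-out could move. Here it moves with no atom or bond changing, which places the step at the saturated chain carbon and ties it to how that centre is drawn, the single difference the two structures offer: the fact that one of compounds 1 and 4 is drawn with a defined configuration and the other without, at the place where they differ

The compounds shown leave open what the undrawn centre of compound 1 stands for in the material tested, and whether the R configuration at this carbon would give a number like that of compound 1 or that of compound 4. They also leave open whether the step would hold with a different group at this chain carbon, such as an ethyl group in place of the methyl, or with a free amine in place of the benzyloxycarbonyl-capped nitrogen.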